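Swapping an amine substituent on a shared indole-triazole core

A few compounds are considered here, and "the series" means these few. Any claim that something is new, unique, unknown or untested is made for them only; others in the source may bear on it.

Compound 1 `CC(C)Sc1nnc(-c2c(CNc3cnccn3)c3ccccc3n2C)n1-c1ccccc1`: 4.22
Compound 2 `CC(C)Sc1nnc(-c2c(CNCC3CC3)c3cc(F)ccc3n2C)n1-c1ccccc1`: 5.4

In a physicochemical assay for lipophilicity (a lower number here means a more polar compound, a higher number a more lipophilic compound), compound 1 gives 4.22, the lower of the two numbers shown, with compound 2 giving 5.4, which lies beyond the scatter above it. Compound 3 `COc1ccc(CNCc2c(-c3nnc(SC(C)C)n3-c3ccccc3)n(C)c3ccccc23)cc1` is not yet measured. It differs from compound 1 in one place (4-methoxybenzyl in place of pyrazin-2-yl on an amine nitrogen). Going by the values given here, no measured pair shows this change, so the expectation rests on the two numbers alone. The step from compound 1 to compound 3 is expected to be an increase, a number 1.08 log units higher from compound 1 to compound 3 (beyond the scatter), clearly beyond the scatter. For compound 3 the estimate is 5.3, between 4.6 and 6.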

Compound 3, partition coefficient: 6.27
The estimate for compound 3 lay 0.97 log units below the measured number, outside the stated range (above it).
By their numbers in this assay, from the lowest: compound 1; then compound 2; then compound 3.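

On an amine nitrogen of the shared core, 4-methoxybenzyl in place of pyrazin-2-yl gives a large rise in this assay, a number 2.05 log units higher from compound 1 to compound 3 (beyond the scatter). This is the only step shown that changes a single place, so it shows that this position alone can move the number well beyond the scatter. No measurement here explains the size of this rise.

The compounds shown do not separate the change of ring from the added methoxy group. A plain benzyl group on the same nitrogen would speak to that.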